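The source may report more compounds than this note shows. Statements on the series, on what has been measured and on what is new or still open speak of the compounds shown alone.

Measured compounds:
- compound 1 `Cc1ccccc1-n1nncc1CN1C(=O)C2(C(C#N)=C(N)Oc3c2c2nc4ccccc4nc2c2ccccc32)c2ccccc21` — > 50000 nM
- compound 2 `N#CC1=C(N)Oc2c(N)cc3nc4ccccc4nc3c2C12C(=O)N(Cc1cnnn1-c1ccccc1Br)c1ccccc12` — 34200 nM

In an ADME assay on HUVEC cells (Homo sapiens) for antiproliferative activity, read by MTT assay, with a stated time of 48 h (on this read-out higher numbers stand for weaker inhibition and lower numbers for stronger inhibition), compound 1 gives only a limit, > 50000 nM, not a number. Compound 2 gives a number in this assay, 34200 nM, and it is the only number shown. The other value shown, that of compound 1, is a limit: the limit of > 50000 nM in this assay, at which 1 of the 2 values shown sits. Among the measured compounds shown here, no step between measured compounds that differ in one place is available, so the size of any change must be guessed rather than read off.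

Compound 3 `N#CC1=C(N)Oc2c(N)cc3nc4ccccc4nc3c2C12C(=O)N(Cc1cnnn1-c1ccc(Cl)cc1[N+](=O)[O-])c1ccccc12` differs from compound 2 at one place: 4-chloro-2-nitrophenyl in place of 2-bromophenyl on an aromatic nitrogen. For the measured compounds named here, no measured pair speaks to this kind of exchange. The step is therefore expected to stay within the usual scatter in this assay, with no direction favoured, so compound 3 is estimated at 35000 nM, between 12000 nM and 100000 nM. This estimate means a step of a 1.0-fold higher number from compound 2 to compound 3 (0.01 log units; within the scatter).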

Compound 3, half-maximal inhibitory concentration: > 50000 nM
Compound 3 was reported as a limit (the forecaster's own chance of this, stated with the estimate: 35%); at least 1.4-fold (0.15 log units) between middle value and limit.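

Replacing 2-bromophenyl with 4-chloro-2-nitrophenyl on the aromatic nitrogen gives an at least 1.4-fold higher number from compound 2 to compound 3 (0.16 log units; that floor lies within the scatter) in this assay. Compound 3 reads only as a limit, so the exchange shows no stronger inhibition at this position, and how far the number rises cannot be told. Only compound 2 now carries a number, while the other values sit at one limit: the limit of > 50000 nM in this assay, at which 2 of the 3 values shown sit.

The compounds shown leave open whether a plain phenyl, a 2-methoxyphenyl or a 2-aminophenyl on this nitrogen would bring a number lower than that of compound 2, 34200 nM. The chloro and nitro groups also enter together in compound 3, and the compounds shown do not separate the two.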